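The source may report more compounds than this note shows. Statements on the series, on what has been measured and on what is new or still open speak of the compounds shown alone.

Going by the values given here, the two compounds measured so far share one core. Compound 1 `Cc1ccccc1C(=O)OC(CCN(C)C)c1ccc(Cl)cc1` gives 1700 nM in an assay on NIH3T3 cells with Urotensin-2 receptor (Homo sapiens) as the target; a lower number here means that less compound is needed, a higher number that more compound is needed for the effect. Compound 2 `Cc1c(Cl)cccc1C(=O)OC(CCN(C)C)c1ccc(Cl)cc1`, which carries a chloro in place of hydrogen on an aromatic carbon, gives 1120 nM in this assay. a 1.5-fold lower number from compound 1 to compound 2 (0.18 log units; within the scatter), so the two numbers cannot be told apart. Compound 2 thus holds the lower of the two numbers, with compound 1 close to it.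

Compound 3 `CN(C)CCC(OC(=O)NCc1ccccc1)c1ccc(Cl)cc1` has not yet been measured. It differs from compound 2 by benzylamino in place of 3-chloro-2-methylphenyl on a carbonyl carbon. Among the compounds with values here, no measured step touches this change: the only step between measured compounds, a 1.5-fold lower number from compound 1 to compound 2 (0.18 log units; within the scatter), concerns a substituent on the aromatic ring that leaves here, and it stayed within the scatter. Within the data shown here, the data therefore offer no direction for this step, and the expectation for compound 3 rests on compound 2 alone, whose value 1120 nM serves as the anchor, with a wide margin to either side. Compound 3 is expected to give about 2000 nM in this assay, in a range from 500 nM to 8000 nM. For compound 3 this estimate means a step of a 1.8-fold higher number from compound 2 to compound 3 (0.25 log units; within the scatter), which is expected to carry no firm direction.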

Compound 3, half-maximal effective concentration: 2140 nM
The estimate for compound 3 lay 1.1-fold (0.03 log units) below the measured number; the measured number falls inside the stated range.
By their numbers in this assay, from the lowest: compounds 2, 1 and 3 (each within the scatter of the next).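

The earlier compounds shown here differed only by a substituent on the aromatic ring attached to the carbonyl carbon, whereas compound 3 replaces that entire group. In this assay, the exchange for benzylamino gives a 1.9-fold higher number from compound 2 to compound 3 (0.28 log units; within the scatter) and, measured against the 2-methylphenyl group, a 1.3-fold higher number from compound 1 to compound 3 (0.10 log units; within the scatter), so neither step separates the numbers, even though a hydrogen-bond donor enters with the same count of heavy atoms and one six-membered aromatic ring of carbon only. At this position, then, an aryl group bonded directly to the carbonyl carbon is not required to keep the number in the same region, and nothing available explains this result.

As far as these compounds go, it remains open whether a methyl on the nitrogen of benzylamino, a longer chain such as phenethylamino or a shorter link such as anilino would also leave the number in that region. It is equally open whether a chloro on the ring of benzylamino would have any effect in this assay, since the one chloro step shown concerns the ring that compound 3 no longer carries.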